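Effect of removing the aromatic methyl from compound 1

The compounds below may be only part of what the source reports. "The series", "measured", "known", "first", "only" and "open" are said of these compounds alone.

Measured in a functional assay on LM7 cells (Homo sapiens) for antiproliferative activity, read by MTT assay, with a stated time of 72 h; on this read-out lower numbers stand for stronger inhibition and higher numbers for weaker inhibition:
compound 1 `Cc1ccc2c(=O)c(CSC(=S)N(C(C)C)C(C)C)coc2c1` gives 6300 nM
compound 2 `Cc1ccc2c(=O)c(CSC(=S)N3CCOCC3)coc2c1` gives 14300 nM
compound 3 `Cc1ccc2c(=O)c(CSC(=S)N3CCCC3)coc2c1` gives 3400 nM

Compound 1 stands second highest of the three numbers. Its nearest neighbour is compound 3, reached by a 1.9-fold lower number from compound 1 to compound 3 (0.27 log units; within the scatter), a step within the scatter. Furthest is compound 2, reached by a 2.3-fold higher number from compound 1 to compound 2 (0.36 log units; beyond the scatter). Between the other two lies a 4.2-fold lower number from compound 2 to compound 3 (0.62 log units; beyond the scatter). Going by the values given here, every one of these measured steps exchanges the group on the thiocarbonyl carbon; none of them alters the six-membered aromatic ring of the shared core, so the aromatic part of the series has not yet been varied.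

Compound 4 `CC(C)N(C(=S)SCc1coc2ccccc2c1=O)C(C)C` differs from compound 1 at one place: hydrogen in place of methyl on an aromatic carbon. Among the compounds with values here, no measured step bears on this change, and nothing in the three numbers points to a direction. The expected step of no change at the digits printed from compound 1 to compound 4 (within the scatter) is therefore no more than the scatter. Compound 4 is expected to give 6300 nM in this assay, with a range from 2500 nM to 16000 nM. Going by these compounds, the change is untested; the range is set wide in both directions.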

Compound 4, half-maximal inhibitory concentration: 21900 nM
Estimate against measurement, compound 4: 3.5-fold (0.54 log units) below, and the stated range ends below it.
By their numbers in this assay, from the lowest: compounds 3 and 1 (each within the scatter of the next); then compounds 2 and 4 (each within the scatter of the next).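

In this assay, hydrogen in place of methyl on an aromatic carbon gives a 3.5-fold higher number from compound 1 to compound 4 (0.54 log units; beyond the scatter) and so moves the read-out beyond the scatter, towards weaker inhibition. Going by these compounds alone, this is the first sign that the six-membered aromatic ring of the shared core bears on the read-out, and not only the group on the thiocarbonyl carbon: a change of one carbon, with no hydrogen-bond donor or acceptor involved, gives a step labelled modest, as is a 4.2-fold lower number from compound 2 to compound 3 (0.62 log units; beyond the scatter) on the thiocarbonyl side. Nothing available explains why the methyl matters at this position.

Within the data shown here, the change from methyl to hydrogen is seen only with the diisopropylamino group, so whether it carries the same weight with the morpholin-4-yl or pyrrolidin-1-yl groups remains open. Also open, going by these compounds, is whether ethyl, methoxy or chlorine on this carbon would give a lower or a higher number than methyl, and whether a methyl on another carbon of the same ring would behave as this one does.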